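A few compounds are considered here, and "the series" means these few. Any claim that something is new, unique, unknown or untested is made for them only; others in the source may bear on it.

Compounds measured so far, with their values in a functional assay on the whole organism (artery, strain albino) with Rattus norvegicus as the target, with a stated time of 120 min, at a dose of 10 mg/kg by the oral route; on this read-out higher numbers stand for more inhibition at the one dose given (going by the name of the read-out) and lower numbers for less inhibition:

Compound 1, `COc1ccc(C2N=C(SCc3cccc(Cl)c3)NC(C)=C2C(=O)Nc2ccc(Br)cc2)cc1`, gives 21.1%.
Compound 2, `COc1ccc(C2N=C(SCc3ccc(Cl)cc3)NC(C)=C2C(=O)Nc2ccc(Br)cc2)cc1`, gives 16.5%.
Compound 3, `CC1=C(C(=O)Nc2ccc([N+](=O)[O-])cc2)C(c2ccc(Br)cc2)N=C(SCc2cccc(Cl)c2)N1`, gives 6.7%.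

Compound 1 and compound 2 share a core and differ in one place: 4-chlorophenyl in place of 3-chlorophenyl on a saturated chain carbon bound to a sulfur. This change gives a number 4.6 percentage points lower from compound 1 to compound 2 (within the scatter), so the two values of compound 1 and compound 2 cannot be told apart by this assay. Compound 3 carries a different core; the difference between the two cores is not broken down here. Compound 3 has the lowest of the three numbers, yet its gap to compound 2 is within the scatter, and only its gap to compound 1 is beyond it.

Compound 4, `CC1=C(C(=O)Nc2ccc([N+](=O)[O-])cc2)C(c2ccc(Br)cc2)N=C(SCc2ccc(Cl)cc2)N1`, has not yet been measured. It differs from compound 3 by 4-chlorophenyl in place of 3-chlorophenyl on a saturated chain carbon bound to a sulfur, and the place of the change is the same, word for word, as between compound 1 and compound 2. Since this change produced only a number 4.6 percentage points lower from compound 1 to compound 2 (within the scatter), the step from compound 3 to compound 4 is expected to be of the same small size, roughly a number 2.7 percentage points lower from compound 3 to compound 4 (within the scatter), resting on that one earlier pair alone. Compound 4 is therefore estimated at 4% in this assay, with a range from -6% to 14%.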

Compound 4, a percentage reported as inhibition, in the whole organism at one dose (the size of the read-out at that dose, not a potency): 13.9%
Estimate against measurement, compound 4: 9.9 percentage points below, within the range that was stated.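

In this assay, putting 4-chlorophenyl in place of 3-chlorophenyl on the second core gives a number 7.2 percentage points higher from compound 3 to compound 4 (within the scatter), so this pair cannot be told apart by the assay, just like the first pair. Set side by side, the two steps do not differ by more than the assay can resolve, and the change can be carried from one core to the other as one that leaves no readable mark: the same change on two cores in this assay, a number 4.6 percentage points lower (within the scatter) from compound 1 to compound 2 and a number 7.2 percentage points higher (within the scatter) from compound 3 to compound 4, 11.8 percentage points apart, within the scatter of two such steps. The opposite directions of the two steps therefore carry no weight, and the result does not show that the change has no effect at all, nor that it would behave alike on any other core.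

The compounds shown leave open what happens when the chlorine gives way to another group, such as a methoxy group, a nitrile or a carboxylic acid, or when a longer chain replaces the benzyl on the sulfur. Among the compounds shown here, they also do not break down the difference between the two cores, with no pair here differing in only one part of it.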